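The source may hold more compounds than are shown below. What is called first, only, known or untested is meant among the compounds shown, and "the series" means these compounds.

Working notes on the series.

Compound 1 `Cc1cn2c(/C=N/NC(=N)N)c(-c3ccsc3)nc2s1` and compound 2 `N=C(N)N/N=C/c1c(-c2ccsc2)nc2sccn12` share the same core and differ only in a hydrogen in place of methyl on an aromatic carbon. In a functional assay on cells (Cancer cell lines, Homo sapiens) for inhibition (a higher number here means a weaker inhibitor of growth, a lower number a stronger inhibitor of growth), compound 1 gives 13800 nM, and compound 2 gives 15100 nM. The step of a 1.1-fold higher number from compound 1 to compound 2 (0.04 log units; within the scatter) shows that removing the methyl group leaves the growth inhibition essentially unchanged. Among the two measured numbers, compound 2 has the highest value, with compound 1 nearest; the two cannot be ordered.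

Compound 3 `N=C(N)N/N=C/c1c(-c2cccs2)nc2sccn12` is not yet measured. The change from compound 2 to compound 3 is thiophen-2-yl in place of thiophen-3-yl on an aromatic carbon. Among the measured compounds shown here, no measured step concerns this change: the only step in hand, a 1.1-fold higher number from compound 1 to compound 2 (0.04 log units; within the scatter), touches a different part of the molecule and lies within the scatter, so it offers no direction for the thiophene exchange. For the measured compounds named here, with the same atoms joined differently and both compounds measured so far at a similar weak level, the expectation for a 1.0-fold lower number from compound 2 to compound 3 (0.00 log units; within the scatter) is no step beyond the scatter. Compound 3 is therefore estimated at 15000 nM, with an expected range from 6000 nM to 40000 nM.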

Compound 3, concentration for 50% growth inhibition: 12900 nM
The estimate for compound 3 lay 1.2-fold (0.07 log units) above the measured number, within the range that was stated.
By their numbers in this assay, from the lowest: compounds 3, 1 and 2 (each within the scatter of the next).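

With thiophen-2-yl in place of thiophen-3-yl on the aromatic carbon next to the ring atom that bears a group of 6 heavy atoms, this assay shows a 1.2-fold lower number from compound 2 to compound 3 (0.07 log units; within the scatter). Among the compounds shown here, the earlier pair spoke only to a methyl group elsewhere on the shared core, so this is the first reading at the thiophene position: here, changing how the thiophene is joined, with the same atoms and the same counts on both sides, produces no step beyond the scatter. No measurement on hand bears on why the two thiophene isomers read alike.

All three compounds lie within the scatter of one another. Going by these compounds, the series does not yet show any change that moves growth inhibition, and it remains open whether this position responds at all. A phenyl ring, a simple amine or a carboxylic acid in place of the thiophene would test this with a different ring or group rather than a rearrangement of the same atoms, and only a step beyond the scatter would show that the position matters.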